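The compounds below may be only part of what the source reports. "The series", "measured", "known", "first", "only" and "open" are said of these compounds alone.

Compound 2 `N#C/N=C(/NCCCNc1ccccn1)NCCSc1ccccc1` gives, in a functional assay on Sf9 cells for antagonist activity at histamine H2 receptor (Homo sapiens), read by scintillation counting and GTPgammaS binding, with a stated time of 90 min (a lower number here means a less potent compound, a higher number a more potent compound, by a factor of ten per unit of this negative logarithm), only a limit, < 5. Compound 1 `N#C/N=C(/NCCCSc1nc(N)n[nH]1)NCCSc1ccccc1` likewise sits at a limit in this assay, namely < 5. Within the data shown here, the single measured step, a step that the two limits leave unreadable from compound 1 to compound 2, is unreadable because the limit of < 5 in this assay, at which 2 of the 2 values shown sit, holds both ends of it. Compound 3 `N#C/N=C(/NCCNc1nccc(N)n1)NCCSc1ccccc1` differs from compound 2 by (4-aminopyrimidin-2-yl)amino in place of ((pyridin-2-yl)amino)methyl on a saturated chain carbon, two bonds along the chain from an amine nitrogen. Among the measured compounds shown here, no measured step resembles this change, and the two limits give neither size nor direction. Compound 3 is estimated at 5, within 4.3 to 5.8. The expected step of a number no lower from compound 2 to compound 3 (the limit leaves the size open) is taken as nothing beyond the scatter, with a value that may again be only a limit.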

Compound 3, negative logarithm of the antagonist equilibrium constant: < 5
Compound 3 ended at the assay's limit; the forecaster's own chance of this, stated with the estimate: 60%; the middle value sits exactly at the limit.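

Among these compounds, no step among compound 1, compound 2 and compound 3 can be read, because all three stop at the same limit: the limit of < 5 in this assay, at which 3 of the 3 values shown sit. The compounds shown leave open the actual potency of each in this assay, and so whether either change shifts it.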